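Halogen exchange on the amide aryl of compound 2

A few compounds are considered here, and "the series" means these few. Any claim that something is new, unique, unknown or untested is made for them only; others in the source may bear on it.

Three amides of the shared core have numbers in a functional assay on SK-BR-3 cells (Homo sapiens) for antiproliferative activity, read by MTT assay, with a stated time of 72 h; on this read-out lower numbers stand for stronger inhibition and higher numbers for weaker inhibition. Compound 1 `Cc1cc(NCCN(C)C)nc2ccc(NC(=O)c3ccc(Cl)c(Cl)c3)cc12` gives 6670 nM. Among the measured compounds shown here, compound 3 `Cc1cc(N2CCN(C)CC2)nc2ccc(NC(=O)c3ccc(Cl)c(Cl)c3)cc12` gives 6320 nM; the single measured step between them, a 1.1-fold lower number from compound 1 to compound 3 (0.02 log units; within the scatter), changes the amine on the core and moves nothing beyond the scatter. Compound 2 `CCN1CCN(c2cc(C)c3cc(NC(=O)c4ccc(Cl)cc4)ccc3n2)CC1` gives 3020 nM, the lowest of the three numbers, with compound 3 nearest and compound 1 furthest, both gaps beyond the scatter. Compound 2 and compound 3 differ in two places at once, so their two values stand side by side without a single step to read from them.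

Compound 4 `CCN1CCN(c2cc(C)c3cc(NC(=O)c4ccc(Br)cc4)ccc3n2)CC1` is not yet measured. Its change from compound 2 is bromo in place of chloro on an aromatic carbon. For the measured compounds named here, no measured step in this small set touches the halogen on the amide aryl; the only step in hand concerns the amine side of the core and is itself within the scatter. With nothing in the series speaking for or against this exchange, the expected step in this assay is none beyond the scatter, a 1.0-fold lower number from compound 2 to compound 4 (0.00 log units; within the scatter). Compound 4 is therefore estimated at 3000 nM, with a range from 1500 nM to 6500 nM.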

Compound 4, half-maximal inhibitory concentration: 6310 nM
Beside the measured number, compound 4's estimate is 2.1-fold (0.32 log units) below it; measured number inside the range.
By their numbers in this assay, from the lowest: compound 2; then compounds 4, 3 and 1 (each within the scatter of the next).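

In this assay, among the compounds shown here, the halogen on the amide aryl turns out not to be a silent place: bromo in place of chloro, on an aromatic carbon para to a large group, gives a 2.1-fold higher number from compound 2 to compound 4 (0.32 log units; beyond the scatter) and so a modest move beyond the scatter, whereas the one earlier step, a 1.1-fold lower number from compound 1 to compound 3 (0.02 log units; within the scatter) at the amine on the core, stayed within it. The exchange replaces one heavy atom with one heavy atom and leaves the counted hydrogen-bond donors and acceptors, the ring count and the net charge of the group unchanged, so a change this small at this place is enough to shift the number in this series. Nothing measured in hand bears on why the number moves.

On these data alone, a single step between two halogens gives no trend, so it remains open where fluoro, methoxy, a nitrile or the plain phenyl amide would fall relative to 4-chlorophenyl and 4-bromophenyl. As far as these compounds go, it is equally open whether the same exchange moves the number to a similar extent when morpholine or another amine replaces the 4-ethylpiperazine on the shared core.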